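This account rests on a few compounds, and the source may have more. Where it says the series, first, only, none or still open, it means among the compounds named here.

Measured compounds in this series:
compound 1, `CC(C)(C)c1cc(CNC(=O)Nc2cccc3[nH]ncc23)n(-c2cccc(Cl)c2)n1`, with 0.6 nM in an assay on CHO-K1 cells for antagonist activity at transient receptor potential cation channel subfamily V member 1 (Homo sapiens), read by FLIPR and calcium flux, with a stated time of 6 min; a higher number here means a weaker inhibitor, a lower number a stronger inhibitor;
compound 2, `CC(C)(C)c1cc(CNC(=O)Nc2cccc3[nH]ncc23)n(-c2ccc(F)cc2)n1`, with 2.2 nM in this assay;
compound 3, `CC(C)(C)c1cc(CNC(=O)Nc2cccc3[nH]ncc23)n(-c2ccc(C(F)(F)F)cc2)n1`, with 19.6 nM in this assay.

Compound 3 stands at the highest number of the three, separated from compound 2 by an 8.9-fold higher number from compound 2 to compound 3 (0.95 log units; beyond the scatter) and from compound 1 by a 33-fold higher number from compound 1 to compound 3 (1.51 log units; beyond the scatter), both beyond the scatter. Compound 4, `CC(C)(C)c1ccc(-n2nc(C(C)(C)C)cc2CNC(=O)Nc2cccc3[nH]ncc23)cc1`, is not yet measured. It differs from compound 3 by tert-butyl in place of trifluoromethyl on an aromatic carbon.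

For the measured compounds named here, no measured step exchanges trifluoromethyl for tert-butyl anywhere. Going by the values given here, the only step at this position is an 8.9-fold higher number from compound 2 to compound 3 (0.95 log units; beyond the scatter), which shows that enlarging the substituent from fluoro to trifluoromethyl raised the number; the change from compound 3 to compound 4 keeps the heavy-atom count of the substituent and changes only its composition. Among the compounds with values here, with no direct precedent, no step beyond the scatter is expected in this assay, and compound 4 is therefore estimated at 20 nM, within 6 nM to 70 nM, corresponding to an expected 1.0-fold higher number from compound 3 to compound 4 (0.01 log units; within the scatter).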

Compound 4, inhibition constant: 40 nM
Compound 4: the middle estimate sits 2.0-fold (0.30 log units) below what was measured; low and high end bracket the measured number.
By their numbers in this assay, from the lowest: compound 1; then compound 2; then compound 3; then compound 4.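

In this assay, tert-butyl in place of trifluoromethyl on the aromatic carbon para to a large group gives a 2.0-fold higher number from compound 3 to compound 4 (0.31 log units; beyond the scatter) even though both groups have the same heavy-atom count, so composition alone moves the number at this position. On this aromatic carbon the number rises from fluoro through trifluoromethyl to tert-butyl, with an 18-fold higher number from compound 2 to compound 4 (1.26 log units; beyond the scatter) across the whole span, and the change from 3-chlorophenyl to 4-(tert-butyl)phenyl gives a 67-fold higher number from compound 1 to compound 4 (1.82 log units; beyond the scatter) as the widest gap in the set. Nothing measured here bears on the cause of these steps.

As far as these compounds go, whether a methoxy group, a nitrile or an amine on this aromatic carbon would follow the same rise remains open. The compounds shown also cannot separate the effect of chloro itself from that of its place in 3-chlorophenyl.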